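The source may hold more compounds than are shown below. What is called first, only, known or untested is meant among the compounds shown, and "the series" means these compounds.

In a functional assay on SKHep cells (Homo sapiens) for antiproliferative activity, read by MTT assay, with a stated time of 12 h (on this read-out higher numbers stand for weaker inhibition and lower numbers for stronger inhibition), compound 3 `COc1cc(OC)c2c(=O)cc(/C=C/c3ccc(F)cc3)oc2c1` gives 29200 nM. Its nearest neighbour is compound 1 `COc1cc(OC)c2c(=O)cc(/C=C/c3ccc(Cl)cc3)oc2c1`, which gives 26900 nM in this assay, and the two stand together, separated only by a 1.1-fold higher number from compound 1 to compound 3 (0.04 log units; within the scatter). Compound 2 `COc1ccc2c(=O)cc(/C=C/c3ccc(OC(F)(F)F)cc3)oc2c1` returns only a limit, > 40000 nM, in this assay. That limit is the one noted at the limit of > 40000 nM in this assay, at which 1 of the 3 values shown sits, so of the three results shown, two are numbers and one is a limit, and compound 3 stands among the numbers rather than at the limit.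

Compound 4 `COc1ccc(/C=C/c2cc(=O)c3c(OC)cc(OC)cc3o2)cc1` has not yet been measured in this assay. It differs from compound 3 in one place: methoxy in place of fluoro on an aromatic carbon.

The only measured step among these compounds, fluoro in place of chloro on an aromatic carbon, is a 1.1-fold higher number from compound 1 to compound 3 (0.04 log units; within the scatter), and it exchanges one halogen for another; it does not touch a methoxy group, so no measured step speaks directly to this change. With nothing in the numbers to push either way, the expectation for compound 4 is a step of a 1.0-fold higher number from compound 3 to compound 4 (0.01 log units; within the scatter) in this assay, that is, no change beyond the ordinary scatter. The estimate for compound 4 is therefore 30000 nM, within a range from 12000 nM to 70000 nM.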

Compound 4, half-maximal inhibitory concentration: > 40000 nM
Compound 4 gave a limit, no number (the forecaster's own chance of this, stated with the estimate: 30%); middle value at least 1.3-fold (0.12 log units) away from the limit.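

In this assay, going by these compounds alone, compound 4 gives > 40000 nM, which is a limit and not a number, and this is the first result at this place on the six-membered aromatic ring, para to a large group, for a group other than a halogen. Against the two halogen compounds, the methoxy group gives an at least 1.3-fold higher number from compound 3 to compound 4 (0.13 log units; that floor lies within the scatter) and an at least 1.4-fold higher number from compound 1 to compound 4 (0.17 log units; that floor lies within the scatter), and since both floors lie within the scatter, the result neither establishes a real loss of inhibition nor excludes one, whereas the earlier step between chloro and fluoro showed only that these two halogens could not be told apart. What the change does show is that going from 4-fluorophenyl to 4-methoxyphenyl moves the read-out from a number to the assay's limit, which is now reached more often among the compounds shown: the limit of > 40000 nM in this assay, at which 2 of the 4 values shown sit.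

On these data alone, how far compound 4 lies past that limit remains open, so the true size of the step cannot be stated. Also open, as far as these compounds go, is whether a hydroxyl group, an amine or a longer alkoxy chain at this same place would return a number or would stay at the limit.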